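Sulfamate pair: bromo replaced by acetyl, expectation

The compounds below may be only part of what the source reports. "The series", "measured", "known", "first", "only" and "open" are said of these compounds alone.

Two compounds have numbers in an assay on liver for inhibition of sterol O-acyltransferase 1 (Rattus norvegicus), using microsomes; a lower number here means a stronger inhibitor, a higher number a weaker inhibitor. Compound 1, `CC(C)c1cccc(C(C)C)c1NC(=O)NS(=O)(=O)N(CC1CCCO1)CC1CCCO1`, gives 1700 nM in this assay. Compound 2, `CC(C)c1cc(Br)cc(C(C)C)c1OC(=O)NS(=O)(=O)Oc1c(C(C)C)cccc1C(C)C`, gives 31000 nM in this assay, the higher of the two numbers; the gap between compound 1 and compound 2 lies beyond the scatter, so compound 2 is the weaker inhibitor of the pair. The two structures do not differ in one place only, so this comparison says nothing more than that compound 2 sits at the weak end of what has been measured.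

Compound 3, `CC(=O)c1cc(C(C)C)c(OC(=O)NS(=O)(=O)Oc2c(C(C)C)cccc2C(C)C)c(C(C)C)c1`, has not yet been measured in this assay. It differs from compound 2 in one place: acetyl in place of bromo on an aromatic carbon. Among the compounds with values here, no measured pair in the set exchanges these two groups, so there is no precedent step to lean on. Without one, the step expected here is a 1.6-fold lower number from compound 2 to compound 3 (0.19 log units; within the scatter), small, within the scatter or close to it, with no firm direction. On that basis compound 3 is estimated at 20000 nM in this assay, within a range from 5000 nM to 80000 nM.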

Compound 3, half-maximal inhibitory concentration: 41800 nM
Compound 3: middle estimate off by 2.1-fold (0.32 log units), on the low side; measured number inside the range.
By their numbers in this assay, from the lowest: compound 1; then compounds 2 and 3 (each within the scatter of the next).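

In this assay, the exchange of bromo for acetyl on this aromatic carbon, meta to two isopropyl groups and para to a large group, is a 1.3-fold higher number from compound 2 to compound 3 (0.13 log units; within the scatter) and leaves the two compounds indistinguishable in this read-out. Within the data shown here, this is the first direct reading at this position: for this one pair, a group of 3 heavy atoms with 1 hydrogen-bond acceptor and a single bromine atom give the same result within the scatter, so the exchange neither gains nor loses measurable inhibition on this core. Nothing in the data shown offers a reason for this flat step.

Going by these compounds, one exchange between two groups cannot show whether the position tolerates substitution in general, and it remains open whether the unsubstituted aromatic carbon, an amine, a carboxylic acid or a longer chain at this place would read the same or would separate from compound 2 beyond the scatter. On these data alone, it also remains open whether the same exchange would stay flat on a core that starts from a lower number than compound 2 at 31000 nM in this series.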